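The source may hold more compounds than are shown below. What is called first, only, known or untested is meant among the compounds shown, and "the series" means these compounds.

Measured so far in an in vitro ADME assay on microsomes from liver (Homo sapiens) for metabolic stability, using NADPH; on this read-out lower numbers stand for slow clearance and higher numbers for fast clearance:
Compound 1 `Cc1ccc(C(F)(F)F)cc1Cn1c(C(=O)NCC(C)(C)CO)cc2cc(C#N)ccc21`: 180 mL.min-1.g-1
Compound 2 `CC(C)(O)CCNC(=O)c1cc2cc(C#N)ccc2n1Cc1cccc(OC(F)(F)F)c1`: 9 mL.min-1.g-1

Of these two, compound 2 stands lowest at 9 mL.min-1.g-1 in this assay, with compound 1 higher by more than the scatter. Compound 3 `N#Cc1ccc2c(c1)cc(C(=O)NCCC(O)C(F)(F)F)n2Cc1cccc(OC(F)(F)F)c1`, not yet measured, differs from compound 2 by one change: 2,2,2-trifluoro-1-hydroxyethyl in place of 1-hydroxy-1-methylethyl on a saturated chain carbon, two bonds along the chain from an amide-type nitrogen. Within the data shown here, no measured pair shows this change, so the expectation is loose: no step beyond the scatter, if anything a small rise. The expected move is a 1.6-fold higher number from compound 2 to compound 3 (0.19 log units; within the scatter) in this estimate. For compound 3 the estimated clearance is 14 mL.min-1.g-1, with an expected range from 6 mL.min-1.g-1 to 35 mL.min-1.g-1.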

Compound 3, intrinsic clearance in microsomes: 59 mL.min-1.g-1
The estimate for compound 3 lay 4.2-fold (0.62 log units) below the measured number, outside the stated range (above it).
By their numbers in this assay, from the lowest: compound 2; then compound 3; then compound 1.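

In this assay, 2,2,2-trifluoro-1-hydroxyethyl in place of 1-hydroxy-1-methylethyl on a saturated chain carbon, two bonds along the chain from an amide-type nitrogen, gives a 6.6-fold higher number from compound 2 to compound 3 (0.82 log units; beyond the scatter). Among these compounds, this is the first step between compounds differing in one place, and it shows that the read-out responds to a change at this position. No measurement shown gives a reason for this rise. As far as these compounds go, whether a plain 1-hydroxyethyl group or an amine in that place would stand nearer compound 2 or compound 3 remains open. From the compounds shown here alone, it is also open whether the same change would give a similar step on the core of compound 1.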